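A few compounds are considered here, and "the series" means these few. Any claim that something is new, unique, unknown or untested is made for them only; others in the source may bear on it.

Measured so far in an ADME assay on BJ cells (Homo sapiens) for antiproliferative activity, with a stated time of 72 h; on this read-out higher numbers stand for an effect only at larger amounts of compound and lower numbers for an effect already at smaller amounts:
- compound 1 (`C=CCNC(=O)n1c(-c2ccc(OC)cc2)cc(=O)c2c(OC)cc(OC)cc21`): 74000 nM
- compound 2 (`COc1ccc(-c2c(I)c(=O)c3c(OC)cc(OC)cc3n2S(=O)(=O)c2ccc(OC)cc2)cc1`): a limit, > 34400 nM
- compound 3 (`COc1ccc(-c2cc(=O)c3c(OC)cc(OC)cc3n2S(=O)(=O)c2ccc([N+](=O)[O-])cc2)cc1`): a limit, > 29300 nM

Compound 3 stands at the limit of > 29300 nM in this assay, at which 1 of the 3 values shown sits. Compound 2 stands at the limit of > 34400 nM in this assay, at which 1 of the 3 values shown sits. Only compound 1 gives a number, and that number lies in the weak range. Compound 4 (`COc1ccc(-c2cc(=O)c3c(OC)cc(OC)cc3n2S(=O)(=O)c2ccc(F)cc2)cc1`) has not been measured in this assay. From compound 3 it differs as fluoro in place of nitro on an aromatic carbon, para to a large group. For the measured compounds named here, no measured pair shows what such an exchange does here. The expected step is a step that the limit leaves unreadable from compound 3 to compound 4, nothing beyond the scatter in either direction. Compound 4 is estimated at 35000 nM, within 10000 nM to 120000 nM, with a further limit the more likely outcome.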

Compound 4, half-maximal effective concentration: > 65500 nM
Compound 4 gave a limit, no number (the forecaster's own chance of this, stated with the estimate: 60%); at least 1.8-fold (0.27 log units) between middle value and limit.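

In this assay, for the compounds shown here, compound 4 gives only a limit, > 65500 nM, so no step from compound 3 or compound 1 to compound 4 can be read. Going by these compounds, whether fluoro in place of nitro changes the read-out at all stays open.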